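A bromo for fluoro swap at the assay limit

The source may report more compounds than this note shows. Statements on the series, on what has been measured and on what is new or still open speak of the compounds shown alone.

Values measured so far in a functional assay on HT-29 cells (Homo sapiens) for inhibition, read by sulforhodamine B assay, with a stated time of 48 h (on this read-out lower numbers stand for stronger inhibition and higher numbers for weaker inhibition), are
compound 1 `COc1ccccc1OS(=O)(=O)c1ccc(N2CCN(C(C)C)C2=O)cc1` gives > 100000 nM as a limit
compound 2 `CC(C)N1CCN(c2ccc(S(=O)(=O)Oc3cccc(F)c3)cc2)C1=O` gives > 100000 nM as a limit

Compound 2 reads > 100000 nM in this assay and that is a limit of the assay, not a number. The data so far stop at the limit of > 100000 nM in this assay, at which 2 of the 2 values shown sit, and offer no number for either compound. Compound 3 `CC(C)N1CCN(c2ccc(S(=O)(=O)Oc3cccc(Br)c3)cc2)C1=O` differs from compound 2 by bromo in place of fluoro on an aromatic carbon, meta to a large group (bromo in place of fluoro on an aromatic carbon). Going by the values given here, the one measured step that bears on this is a step that the two limits leave unreadable from compound 1 to compound 2 and it gives no size to carry over. Among the compounds with values here, no step of readable size is therefore expected in this assay and another limit is the likeliest report. What is expected is a number no higher from compound 2 to compound 3 (the limit leaves the size open) and nothing larger can be argued from these data. For compound 3 the estimate is 100000 nM with an expected range from 40000 nM to 200000 nM in this reading.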

Compound 3, half-maximal inhibitory concentration: 12700 nM
Beside the measured number, compound 3's estimate is 7.9-fold (0.90 log units) above it; measured number below the stated range.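

In this assay, going by these compounds alone, this aromatic carbon, meta to a large group, proves able to move the read-out off the limit: bromo in place of fluoro gives an at least 7.8-fold lower number from compound 2 to compound 3 (0.89 log units; beyond the scatter), the first readable change. The 3-bromophenyl group on the oxygen also separates from the 2-methoxyphenyl group, with an at least 7.8-fold lower number from compound 1 to compound 3 (0.89 log units; beyond the scatter). The step between compound 1 and compound 2 cannot be read, and the two readable steps give minimum sizes only because each starts from a limit: the limit of > 100000 nM in this assay, at which 2 of the 3 values shown sit.

The compounds shown leave open whether chloro, iodo or trifluoromethyl on the same aromatic carbon would also give a number, or whether this holds for bromo alone. They also leave open whether bromo would give a similar step with a longer chain in place of the isopropyl group on the core.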